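The source may hold more compounds than are shown below. What is called first, only, known or untested is meant among the compounds shown, and "the series" means these compounds.

Working notes on the series.

Compound 1 `COc1ccc(-n2c(-c3cc(OC)c(OC)c(OC)c3)csc2=O)cc1[N+](=O)[O-]` carries a nitro group and in a functional assay on CCRF-CEM cells (Homo sapiens) for antiproliferative activity, with a stated time of 72 h (on this read-out lower numbers stand for stronger inhibition and higher numbers for weaker inhibition), compound 1 gives 2700 nM. Compound 2 `COc1ccc(-n2c(-c3cc(OC)c(OC)c(OC)c3)csc2=O)cc1N` is the same skeleton with the amino group instead, and in this assay compound 2 gives 10100 nM. The change between them, (amino in place of nitro on an aromatic carbon), makes a step of a 3.7-fold higher number from compound 1 to compound 2 (0.57 log units; beyond the scatter).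

Compound 3 `COc1ccc(-c2csc(=O)n2-c2cc(OC)c(OC)c(OC)c2)cc1[N+](=O)[O-]` has the same atoms as compound 1 joined differently; how the two cores differ is not broken down here. In this assay compound 3 gives 8200 nM, which places it within the scatter of compound 2 and beyond the scatter of compound 1.

Compound 4 `COc1ccc(-c2csc(=O)n2-c2cc(OC)c(OC)c(OC)c2)cc1N` stands to compound 3 as compound 2 stands to compound 1: the change amino in place of nitro on an aromatic carbon is the same one, at the same kind of position. Going by the values given here, on the one measured example, a 3.7-fold higher number from compound 1 to compound 2 (0.57 log units; beyond the scatter), a step of similar size and direction is expected here, so that for compound 4 a step of a 3.0-fold higher number from compound 3 to compound 4 (0.48 log units; beyond the scatter) is estimated in this assay. Among the compounds with values here, the estimate for compound 4 in this assay is 25000 nM, expected within 10000 nM to 60000 nM, resting on the single paired step and on compound 3 already giving a weaker number, which raises the chance that only a limit is reported.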

Compound 4, half-maximal inhibitory concentration: 240 nM
Estimate against measurement, compound 4: 100-fold (2.02 log units) above; measured number outside the range, below it.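

In this assay, amino in place of nitro on an aromatic carbon gives a 34-fold lower number from compound 3 to compound 4 (1.53 log units; beyond the scatter), so the change does not carry over between these two cores in either size or direction: the same change on two cores in this assay, a 3.7-fold higher number (0.57 log units; beyond the scatter) from compound 1 to compound 2 and a 34-fold lower number (1.53 log units; beyond the scatter) from compound 3 to compound 4, 130-fold (2.11 log units) apart, beyond the scatter of two such steps

This shows that, for these two pairs, the outcome of the change depends on the core that carries it, and the step on the core of compound 1 gives no usable forecast for the core of compound 3. It does not show what makes the cores differ, and with one pair per core it says nothing about the change on any other core.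

The compounds shown leave open whether the reversal belongs to amino alone or would also appear with a hydroxyl, methylamino or acetamido group on the same aromatic carbon. Compound 4 gives 240 nM, and the compounds shown also leave open whether that value would hold with an ethoxy group in place of the methoxy group to which the amino stands ortho.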